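The source may report more compounds than this note shows. Statements on the series, on what has been measured and on what is new or still open speak of the compounds shown alone.

Compounds measured so far:
- compound 1, `O=C1NCCN1c1ccc(S(=O)(=O)Nc2ccc(F)c(F)c2)cc1`: 620 nM
- compound 2, `COc1ccccc1NS(=O)(=O)c1ccc(N2CCNC2=O)cc1`: 770 nM
- compound 3, `CC(C)(C)c1ccc(NS(=O)(=O)c2ccc(N3CCNC3=O)cc2)cc1`: > 1000 nM

In a functional assay on MCF7 cells (Homo sapiens) for antiproliferative activity, read by sulforhodamine B assay, with a stated time of 48 h (a lower number here means a stronger inhibitor, a higher number a weaker inhibitor), compound 1 gives 620 nM. Of the two numbers reported, compound 1 has the smaller, but a 1.2-fold higher number from compound 1 to compound 2 (0.09 log units; within the scatter) is within the scatter, so compound 1 and compound 2 cannot be told apart on these data. Compound 3 reaches only a limit of the assay, > 1000 nM, and no number is known for it; this is the situation of the limit of > 1000 nM in this assay, at which 1 of the 3 values shown sits.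

The compound still to be measured is compound 4, `O=C1NCCN1c1ccc(S(=O)(=O)Nc2ccc(Cl)cc2)cc1`. It differs from compound 1 in one place: 4-chlorophenyl in place of 3,4-difluorophenyl on a sulfonamide nitrogen. Going by the values given here, the one measured step on the sulfonamide nitrogen, a 1.2-fold higher number from compound 1 to compound 2 (0.09 log units; within the scatter), exchanged one aryl group for another and stayed within the scatter, while compound 3 with its tert-butyl-bearing aryl group sits at the limit. Compound 4 carries a halogenated phenyl ring much like compound 1, so no step beyond the scatter in this assay is expected in either direction. The estimate for compound 4 is 700 nM, within a range of 350 nM to 1400 nM, which is expected to correspond to a 1.1-fold higher number from compound 1 to compound 4 (0.05 log units; within the scatter).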

Compound 4, half-maximal inhibitory concentration: 170 nM
Compound 4: the middle estimate sits 4.1-fold (0.61 log units) above what was measured, outside the stated range (below it).
By their numbers in this assay, from the lowest: compound 4; then compounds 1 and 2 (each within the scatter of the next). At a limit, above all of these: compound 3.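

In this assay, the aryl group on the sulfonamide nitrogen proves able to move the number beyond the scatter: 4-chlorophenyl in place of 3,4-difluorophenyl gives a 3.6-fold lower number from compound 1 to compound 4 (0.56 log units; beyond the scatter), and 4-chlorophenyl in place of 2-methoxyphenyl gives a 4.5-fold lower number from compound 2 to compound 4 (0.66 log units; beyond the scatter). The earlier exchange at this nitrogen had left compound 1 and compound 2 indistinguishable, and compound 4 now shows that two halogen-bearing phenyl groups need not read alike here, so a halogen on the ring does not by itself fix the number. Chloro in place of tert-butyl on an aromatic carbon gives an at least 5.8-fold lower number from compound 3 to compound 4 (0.76 log units; beyond the scatter), a step that marks only a minimum size, as compound 3 stands at a limit of the assay and has no exact number: the limit of > 1000 nM in this assay, at which 1 of the 4 values shown sits.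

The compounds shown leave open whether the kind of halogen or its place on the ring goes with the lower number, as compound 4 differs from compound 1 in both. From the compounds shown here alone, how a bromo, nitrile, amine or carboxylic acid group on that aromatic carbon would read in this assay also remains open.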